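Carboxy Replaces Methoxy on the Fused Ring

This account rests on a few compounds, and the source may have more. Where it says the series, first, only, none or still open, it means among the compounds named here.

Compound 1 `O=C(O)CC(Cc1nc2cc(Cl)ccc2[nH]1)c1ccc(Cl)cc1` gives 0% in an assay on isolated protein for inhibition of protein kinase C zeta type (Homo sapiens), read by 33P incorporation, tested at 50 uM; a lower number here means a weaker effect, a higher number a stronger effect of the compound at the concentration tested. Compound 2 `COc1ccc2[nH]c(CC(CC(=O)O)c3ccc(Cl)cc3)nc2c1`, which carries a methoxy in place of chloro on an aromatic carbon, gives 0% in this assay, and the step of no change at the digits printed from compound 1 to compound 2 (within the scatter) stays within the scatter. Compound 2 therefore stands level with compound 1 at the digits shown, with no measurable inhibition in either case. Compound 3 `O=C(O)CC(Cc1nc2cc(C(=O)O)ccc2[nH]1)c1ccc(Cl)cc1` differs from compound 2 by carboxy in place of methoxy on an aromatic carbon. Among the measured compounds shown here, the only measured step that touches this position is no change at the digits printed from compound 1 to compound 2 (within the scatter), and it was flat; no carboxy group has yet been tested at this place. Because compound 2 gives 0% and the change at the same aromatic carbon gave no change at the digits printed from compound 1 to compound 2 (within the scatter), no step beyond the scatter is expected here. The step of no change at the digits printed from compound 2 to compound 3 (within the scatter) is expected to be essentially nothing. Compound 3 is expected to give 0%, within a range from 0% to 10%.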

Compound 3, a percentage reported as inhibition, at one concentration (the size of the read-out at that concentration, not a potency): 0%
The estimate for compound 3 equals the measured number at the digits printed, and the stated range covers the measured number.
By their numbers in this assay, from the lowest: compounds 1, 2 and 3 (each within the scatter of the next).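

Carboxy in place of methoxy gives no change at the digits printed from compound 2 to compound 3 (within the scatter) in this assay and carboxy in place of chloro gives no change at the digits printed from compound 1 to compound 3 (within the scatter) on the same aromatic carbon. Carboxy brings a hydrogen-bond donor that methoxy does not have, yet compound 3 shows no inhibition at the concentration tested, so none of the three groups at this place separates itself from the others. No measurement at hand offers an explanation for this flat result. Going by these compounds, whether an amine or an amide on this aromatic carbon would give any inhibition remains open. On these data alone, with all three compounds showing none, it is also open whether a change elsewhere in the shared core, such as a longer chain carrying the carboxylic acid or a fluoro in place of chloro on the other aromatic ring, would lift the read-out.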